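The source may hold more compounds than are shown below. What is called first, only, known or untested is meant among the compounds shown, and "the series" means these compounds.

Measured in an ADME assay on J774 cells (Mus musculus) for antiproliferative activity, with a stated time of 72 h; on this read-out higher numbers stand for an effect only at larger amounts of compound and lower numbers for an effect already at smaller amounts:
- Compound 1 `CCc1c(C)[nH]c2cc(OCCOc3ccccc3)ccc2c1=O`: 4000 nM
- Compound 2 `CCCCc1cc2c(=O)c(-c3ccccc3)c(C)[nH]c2cc1OCCOc1ccccc1`: 23000 nM
- Compound 3 `CCCCc1cc2c(=O)c(-c3ccc(C(F)(F)F)cc3)c(C)[nH]c2cc1OCCOc1ccccc1`: 20000 nM

Compound 3, at 20000 nM, lies within the scatter of compound 2 and carries a clearly higher number than compound 1, which reads 4000 nM. The next compound, compound 4 `CCCCc1cc2c(=O)c(-c3ccc(Cl)cc3C)c(C)[nH]c2cc1OCCOc1ccccc1`, has not yet been measured. It differs from compound 3 in one place, with 4-chloro-2-methylphenyl in place of 4-(trifluoromethyl)phenyl on an aromatic carbon.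

For the measured compounds named here, only one measured step touches this aryl group. That step, trifluoromethyl in place of hydrogen on an aromatic carbon, is a 1.2-fold lower number from compound 2 to compound 3 (0.06 log units; within the scatter), and it stays within the scatter. Going by the values given here, compound 1 differs from the others in more than one place, so it offers no single step to compare. Among the compounds with values here, no measured step shows what chlorine or methyl does on this group, which leaves the estimate resting on one small step and on compound 3 at 20000 nM. In this assay, no change beyond the scatter is therefore expected, and the estimated step is a 1.1-fold lower number from compound 3 to compound 4 (0.05 log units; within the scatter). For compound 4 the expected value is 18000 nM, with an estimated range from 8000 nM to 38000 nM.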

Compound 4, half-maximal effective concentration: > 21000 nM
Compound 4 ended at the assay's limit (the forecaster's own chance of this, stated with the estimate: 10%); at least 1.1-fold (0.06 log units) between middle value and limit.
By their numbers in this assay, from the lowest: compound 1; then compounds 3 and 2 (each within the scatter of the next).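

In this assay compound 4 gives > 21000 nM, which is a limit of the assay and not a number: the limit of > 21000 nM in this assay, at which 1 of the 4 values shown sits. For the compounds shown here, the one step that can be read at this aryl group is an at least 1.0-fold higher number from compound 3 to compound 4 (0.02 log units; that floor lies within the scatter), so the change from 4-(trifluoromethyl)phenyl to 4-chloro-2-methylphenyl brings no lower number, while how far the number rises remains unknown. The step from compound 2 to compound 4 cannot be read, so the earlier picture of a single trifluoromethyl exchange within the scatter is extended by a second, larger change of this group that also gives no sign of an effect at smaller amounts.

The compounds shown do not separate the chlorine from the methyl in 4-chloro-2-methylphenyl, and they leave open what an amine or a carboxylic acid on this aryl group would do in this assay. Going by these compounds alone, they also offer no single-place step that links the others to compound 1, at 4000 nM, so what sets its number apart stays unresolved.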